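A few compounds are considered here, and "the series" means these few. Any claim that something is new, unique, unknown or untested is made for them only; others in the source may bear on it.

Of the compounds shown here, three sharing one core have been measured in an assay on brain for displacement of a labelled ligand from D(3) dopamine receptor (Rattus norvegicus); on this read-out higher numbers stand for weaker inhibition and lower numbers for stronger inhibition. Compound 1 `CCCN(CC[C@H]1CC[C@H](NC(=O)/C=C/c2cccc(F)c2)CC1)[C@H]1CCc2nc(N)sc2C1` gives 9.9 nM. Compound 2 `CCCN(CC[C@H]1CC[C@H](NC(=O)c2ccc3ccccc3n2)CC1)[C@H]1CCc2nc(N)sc2C1` gives 1.6 nM. Compound 3 `CCCN(CC[C@H]1CC[C@H](NC(=O)c2ccc(-n3cccn3)cc2)CC1)[C@H]1CCc2nc(N)sc2C1` gives 3 nM. Among these three numbers compound 3 stands second highest: the step of a 1.9-fold higher number from compound 2 to compound 3 (0.27 log units; within the scatter) is within the scatter, whereas the step of a 3.3-fold lower number from compound 1 to compound 3 (0.52 log units; beyond the scatter) lies beyond it, as does a 6.2-fold lower number from compound 1 to compound 2 (0.79 log units; beyond the scatter).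

Compound 4 `CCCN(CC[C@H]1CC[C@H](NC(=O)c2ccc(-c3noc(CC)n3)cc2)CC1)[C@H]1CCc2nc(N)sc2C1` differs from compound 3 in one place: 5-ethyl-1,2,4-oxadiazol-3-yl in place of 1H-pyrazol-1-yl on an aromatic carbon. Among the compounds with values here, no measured step exchanges one five-membered aromatic ring for another on this phenyl ring, so the closest guide is how the amide substituent as a whole has behaved. The two modest steps of a 6.2-fold lower number from compound 1 to compound 2 (0.79 log units; beyond the scatter) and a 3.3-fold lower number from compound 1 to compound 3 (0.52 log units; beyond the scatter) both lowered the number, and the step between the two aromatic amides, a 1.9-fold higher number from compound 2 to compound 3 (0.27 log units; within the scatter), stayed within the scatter. On that basis the author expects no step beyond the scatter in this assay, which the estimate expresses as no change at the digits printed from compound 3 to compound 4 (within the scatter). Compound 4 is therefore estimated at 3 nM in this assay, with an expected range from 1 nM to 10 nM.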

Compound 4, inhibition constant: 2.1 nM
Compound 4: the middle estimate sits 1.4-fold (0.15 log units) above what was measured, and the stated range covers the measured number.
By their numbers in this assay, from the lowest: compounds 2, 4 and 3 (each within the scatter of the next); then compound 1.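

In this assay, 5-ethyl-1,2,4-oxadiazol-3-yl in place of 1H-pyrazol-1-yl on an aromatic carbon, para to a large group, gives a 1.4-fold lower number from compound 3 to compound 4 (0.15 log units; within the scatter). This is the first step shown that alters only the group on this six-membered aromatic ring, not the whole amide substituent, and it shows that the place accepts a five-membered aromatic ring with 3 hetero atoms and 7 heavy atoms, where 1H-pyrazol-1-yl has 2 hetero atoms and 5 heavy atoms, with no step beyond the scatter. Nothing available explains why the number stays within the scatter across this exchange.

The ring and the ethyl group enter together in this single step, so the compounds shown do not separate what each contributes. As far as these compounds go, it also remains open how this assay would respond to a longer chain such as butyl in place of the ethyl group, or to an amine or a carboxylic acid on this same aromatic carbon in place of the five-membered ring.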